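The source may report more compounds than this note shows. Statements on the series, on what has been measured and on what is new or still open speak of the compounds shown alone.

Measured in an ADME assay on HOS cells (Homo sapiens) for cytotoxicity; a lower number here means that less compound is tolerated, a higher number that more compound is tolerated:
- compound 1 `CN1CCC(n2c(CN(C)C3CCCc4cccnc43)nc3ccccc32)CC1`: 16000 nM
- compound 2 `CN(Cc1nc2ccccc2n1CC1CCNC1)C1CCCc2cccnc21`: 7700 nM
- compound 3 `CN1CCCC(Cn2c(CN(C)C3CCCc4cccnc43)nc3ccccc32)C1`: 3000 nM

Compound 3 stands lowest of the three in this assay. Compound 4 `CN1CC(Cn2c(CN(C)C3CCCc4cccnc43)nc3ccccc32)C1` has not yet been measured, and it differs from compound 3 as follows: 1-methylazetidin-3-yl in place of 1-methylpiperidin-3-yl on a saturated chain carbon bound to an aromatic nitrogen. Going by the values given here, the closest evidence is a 2.6-fold lower number from compound 2 to compound 3 (0.41 log units; beyond the scatter), where the four-membered ring of compound 4 has no counterpart, and only pyrrolidin-3-yl gives way to 1-methylpiperidin-3-yl at this place. The other measured steps, a 2.1-fold lower number from compound 1 to compound 2 (0.32 log units; beyond the scatter) and a 5.3-fold lower number from compound 1 to compound 3 (0.73 log units; beyond the scatter), also change the group on the aromatic nitrogen and were modest. Read in reverse, the closest step points to a modest rise, so the expected step is a 2.0-fold higher number from compound 3 to compound 4 (0.30 log units; within the scatter). Compound 4 is estimated at 6000 nM, with an expected range from 2500 nM to 14000 nM.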

Compound 4, half-maximal cytotoxic concentration: 14000 nM
Compound 4: middle estimate off by 2.3-fold (0.37 log units), on the low side; the range from low to high includes it.
By their numbers in this assay, from the lowest: compound 3; then compounds 2, 4 and 1 (each within the scatter of the next, the first and the last beyond it).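

In this assay, this position on a saturated chain carbon bound to an aromatic nitrogen can also raise the number: 1-methylazetidin-3-yl gives a 4.7-fold higher number from compound 3 to compound 4 (0.67 log units; beyond the scatter) and so reverses the fall seen with 1-methylpiperidin-3-yl. Going by these compounds alone, the other steps, a 1.8-fold higher number from compound 2 to compound 4 (0.26 log units; within the scatter) and a 1.1-fold lower number from compound 1 to compound 4 (0.06 log units; within the scatter), leave compound 3 as the only compound beyond the scatter of compound 4 here. Nothing measured explains this rise.

Still open, from the compounds shown here alone, is how a 1-methylpyrrolidin-3-yl group or an unmethylated azetidin-3-yl group would stand at this place. Going by these compounds, it is also open whether the ring's methyl group on nitrogen matters.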